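A few compounds are considered here, and "the series" means these few. Any claim that something is new, unique, unknown or untested is made for them only; others in the source may bear on it.

Working notes on the ester series.

Compound 1 `CCCCOC(=O)c1cccc(-c2cc(C(=O)Nc3ccncc3)ccc2CN)c1` is measured in an assay on isolated protein for inhibition of Rho-associated protein kinase 2 (Homo sapiens), read by radiometric assay (on this read-out higher numbers stand for weaker inhibition and lower numbers for stronger inhibition), and gives 5.5 nM. Compound 2 `CCCCCCOC(=O)c1cccc(-c2cc(C(=O)Nc3ccncc3)ccc2CN)c1` gives 22 nM. The change hydrogen in place of ethyl on a saturated chain carbon, four bonds along the chain from an oxygen next to a carbonyl group gives a 4.0-fold lower number from compound 2 to compound 1 (0.60 log units; beyond the scatter).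

Compound 3 `CCCOC(=O)c1cccc(-c2cc(C(=O)Nc3ccncc3F)ccc2CN)c1` gives 5.1 nM, and its values against compound 1 lie within the scatter of each other. The difference between the core of compound 3 and the core of compound 2 is not broken down here.

Compound 4 `COC(=O)c1cccc(-c2cc(C(=O)Nc3ccncc3F)ccc2CN)c1` is not yet measured. It differs from compound 3 by hydrogen in place of ethyl on a saturated chain carbon bound to an oxygen next to a carbonyl group. Within the data shown here, this is the same kind of change as the one from compound 2 to compound 1, not the same: there the ethyl left a saturated chain carbon four bonds along the chain from an oxygen next to a carbonyl group, here it leaves a saturated chain carbon bound to an oxygen next to a carbonyl group.

The earlier step was a 4.0-fold lower number from compound 2 to compound 1 (0.60 log units; beyond the scatter); for compound 4 a smaller step is expected, a 1.3-fold lower number from compound 3 to compound 4 (0.11 log units; within the scatter), since the shorter chain is already near the better end in compound 1 and compound 3. Compound 4 is estimated at 4 nM, with 1.5 nM to 12 nM as the likely range.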

Compound 4, half-maximal inhibitory concentration: 7.8 nM
The estimate for compound 4 lay 2.0-fold (0.29 log units) below the measured number; low and high end bracket the measured number.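

The loss of ethyl does not carry over as a fixed step between the two cores in this assay: the same change on two cores in this assay, a 4.0-fold lower number (0.60 log units; beyond the scatter) from compound 2 to compound 1 and a 1.5-fold higher number (0.18 log units; within the scatter) from compound 3 to compound 4, 6.1-fold (0.79 log units) apart, beyond the scatter of two such steps

Here propyl to methyl gives a 1.5-fold higher number from compound 3 to compound 4 (0.18 log units; within the scatter), so shortening the ester chain need not bring a lower number on every core in this series. The pair does not show that the core alone accounts for the gap: the ethyl also leaves a different place, bound to an oxygen next to a carbonyl group rather than four bonds along the chain from that oxygen, and one step on each core cannot separate these two differences.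

The compounds shown leave open how propyl to methyl would read on the core of compound 1, and how a longer chain would read on the core of compound 3. Also open, as far as these compounds go, is what a carboxylic acid or an amide would give in place of the propoxycarbonyl group.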